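Hydroxyethyl substitution on the exocyclic amine of the pyrrolidine series

The source may report more compounds than this note shows. Statements on the series, on what has been measured and on what is new or still open speak of the compounds shown alone.

Measured so far:
- compound 1, `C[C@H](O)NC[C@H]1NC[C@H](O)[C@@H]1O`: 488000 nM
- compound 2, `NC[C@H]1NC[C@H](O)[C@@H]1O`: 1590 nM

Compound 1 and compound 2 differ only at the amine nitrogen outside the ring. In an assay on isolated protein for inhibition of endoplasmic reticulum mannosyl-oligosaccharide 1,2-alpha-mannosidase (Homo sapiens) (on this read-out lower numbers stand for stronger inhibition and higher numbers for weaker inhibition), compound 1 gives 488000 nM, while compound 2 gives 1590 nM. The step of a 310-fold lower number from compound 1 to compound 2 (2.49 log units; beyond the scatter) is the only measured one in the set, and it places compound 2 as the lowest of the two numbers, with compound 1 far above it.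

Compound 3, `C[C@@H](O)NC[C@H]1NC[C@H](O)[C@@H]1O`, is not yet measured. Relative to compound 2 the change is 1-hydroxyethyl in place of hydrogen on an amine nitrogen. The group that enters carries the same name as the one removed in going from compound 1 to compound 2, though compound 3 is not compound 1 itself; the entering group has its own defined stereocentre. Among the measured compounds shown here, the only step that bears on this change is a 310-fold lower number from compound 1 to compound 2 (2.49 log units; beyond the scatter), read in reverse: putting 1-hydroxyethyl on this nitrogen went with a large rise in the number. On that basis compound 3 is expected to show a large increase in this assay relative to compound 2, of the order of a 50-fold higher number from compound 2 to compound 3 (1.70 log units; beyond the scatter), with room for a smaller rise given that the measured comparison rests on a single pair. The estimate for compound 3 is 80000 nM, within 8000 nM to 500000 nM.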

Compound 3, inhibition constant: 918000 nM
Compound 3: middle estimate off by 11-fold (1.06 log units), on the low side, and the stated range ends below it.
By their numbers in this assay, from the lowest: compound 2; then compounds 1 and 3 (each within the scatter of the next).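

In this assay, 1-hydroxyethyl in place of hydrogen on an amine nitrogen gives a 580-fold higher number from compound 2 to compound 3 (2.76 log units; beyond the scatter), so the large rise that rested on a single pair now appears with both drawn configurations of the entering group. The configuration at the stereocentre of that group makes no readable difference at this nitrogen: a 1.9-fold higher number from compound 1 to compound 3 (0.27 log units; within the scatter) lies within the usual scatter, and no preference between the two forms can be claimed from these data. The large rise therefore goes with 1-hydroxyethyl on this nitrogen in either drawn form, rather than with one configuration alone, and this reading of the pair rests on the following: the fact that compounds 1 and 3 differ only in the configuration as drawn

The compounds shown do not separate the contribution of the hydroxyl from that of the carbon atoms in the entering group, so an ethyl group or a 2-hydroxyethyl chain on this nitrogen would be the informative comparison. As far as these compounds go, it also remains open whether a smaller methyl group, a longer chain or an acetyl amide at the same nitrogen would stay near compound 2 or move towards compounds 1 and 3.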